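Swapping the Pyridyl Group on a Shared Core

The source may report more compounds than this note shows. Statements on the series, on what has been measured and on what is new or still open speak of the compounds shown alone.

Compound 1 `CCCN(CCC)c1cc(C)nc2c(-c3ccc(Cl)cn3)c(C)nn12`: 88 nM
Compound 2 `CCCN(CCC)c1cc(C)nc2c(-c3ncc(F)cc3C)c(C)nn12`: 19 nM

Going by the values given here, in an assay on isolated protein for binding affinity to corticotropin-releasing factor receptor 1 (Homo sapiens) (a lower number here means a stronger inhibitor, a higher number a weaker inhibitor), compound 2 stands at the lowest of the two numbers, and the only measured step is a 4.6-fold lower number from compound 1 to compound 2 (0.67 log units; beyond the scatter). Compound 3 `CCCN(CCC)c1cc(C)nc2c(-c3ncc(C)cc3O)c(C)nn12` differs from compound 2 in one place: 3-hydroxy-5-methylpyridin-2-yl in place of 5-fluoro-3-methylpyridin-2-yl on an aromatic carbon. Among the compounds with values here, that single step shows that altering the pyridyl group at this position moves the number modestly, yet no measured pair shows what a hydroxyl group there brings, so the direction is uncertain. Compound 3 is expected to show a 2.1-fold higher number from compound 2 to compound 3 (0.32 log units; beyond the scatter). For compound 3 the estimate is 40 nM, ranging from 10 nM to 200 nM.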

Compound 3, inhibition constant: > 10000 nM
Compound 3: no number, only a limit (the forecaster's own chance of this, stated with the estimate: 5%); at least 250-fold (2.39 log units) between middle value and limit.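

In this assay compound 3 gives only a limit, not a number: the limit of > 10000 nM in this assay, at which 1 of the 3 values shown sits. Even so, the steps are large, with an at least 520-fold higher number from compound 2 to compound 3 (2.72 log units; beyond the scatter) and an at least 110-fold higher number from compound 1 to compound 3 (2.05 log units; beyond the scatter). The pyridyl group at this position therefore governs the result far more sharply than the modest first step showed, and 3-hydroxy-5-methylpyridin-2-yl is a poor exchange on this shared core.

The compounds shown leave open whether the hydroxyl group alone carries this loss, since the fluorine also departs in the same step. They also leave open whether a methoxy group or an amine in place of the hydroxyl would fare the same.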